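A few compounds are considered here, and "the series" means these few. Any claim that something is new, unique, unknown or untested is made for them only; others in the source may bear on it.

Of the compounds shown here, two built on one shared core have been tested in a functional assay on HCT-15 cells (Homo sapiens) for cytotoxicity, read by CCK-8 assay and cell counting, with a stated time of 2 days; on this read-out lower numbers stand for stronger inhibition and higher numbers for weaker inhibition. Compound 1, `Oc1ccc(-c2cc(-c3ccc(Cl)cc3)nc(-c3cccnc3)c2)cc1`, gives in this assay a value of 20700 nM. Compound 2, `Oc1cccc(-c2cc(-c3ccc(Cl)cc3)nc(-c3cccs3)c2)c1`, gives in this assay a value of 9280 nM. Of these two numbers compound 2 holds the lower one, and the gap to compound 1, its nearest neighbour, lies beyond the usual scatter of such measurements.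

Compound 3, `Oc1cccc(-c2cc(-c3ccc(Cl)cc3)nc(-c3cccnc3)c2)c1`, has not yet been measured in this assay. It is reached from compound 2 by a single exchange: pyridin-3-yl in place of thiophen-2-yl on an aromatic carbon. For the measured compounds named here, no pair of measured compounds differs by this exchange alone, since compound 1 and compound 2 differ from each other in more than one place, so the two values shown give no direct reading of it. With compound 1 carrying the same pyridin-3-yl group and returning the higher of the two numbers, the expected step of a 1.6-fold higher number from compound 2 to compound 3 (0.21 log units; within the scatter) is toward a weaker number and of modest size, possibly within the scatter. Compound 3 is therefore expected to give about 15000 nM, within a range from 5000 nM to 45000 nM.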

Compound 3, half-maximal inhibitory concentration: 16800 nM
Compound 3: middle estimate off by 1.1-fold (0.05 log units), on the low side, within the range that was stated.
By their numbers in this assay, from the lowest: compounds 2, 3 and 1 (each within the scatter of the next, the first and the last beyond it).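

In this assay, for the compounds shown here, the exchange on the aromatic carbon next to the ring nitrogen can now be read on its own for the first time: putting pyridin-3-yl in place of thiophen-2-yl gives a step that stays inside the normal noise of the measurement (a 1.8-fold higher number from compound 2 to compound 3 (0.26 log units; within the scatter)). Compound 3 also makes a second single change readable, since 3-hydroxyphenyl in place of 4-hydroxyphenyl likewise gives a step inside that noise (a 1.2-fold lower number from compound 1 to compound 3 (0.09 log units; within the scatter)), so neither exchange, taken alone, shows a clear effect on this read-out. No accompanying measurement is available to explain these numbers.

From the compounds shown here alone, these two aromatic rings, thiophen-2-yl and pyridin-3-yl, are a narrow sample of what this position could carry, so it remains open whether a plain phenyl ring, a primary amine or a carboxylic acid placed there would move the number clearly in either direction. Going by these compounds, the role of the 4-chlorophenyl group also remains open, since it is the same in all three compounds, and a methoxy or a fluoro group in place of its chlorine would be needed to test it.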